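Allyl to ethyl: the step from compound 2 to compound 4

The compounds below may be only part of what the source reports. "The series", "measured", "known", "first", "only" and "open" are said of these compounds alone.

Measured so far:
Compound 1 `C=CCn1c(SCC(=O)Nc2ccc(C(C)=O)cc2)nnc1-c1ccccc1` gives 52% in a functional assay on the whole organism (strain albino) for inhibition, with Rattus norvegicus as the target, read by paw edema, with stated times of 30 min and 2 h, at a dose of 0.28 mmol/kg by the oral route; a lower number here means less inhibition, a higher number more inhibition at the dose given (going by the name of the read-out).
Compound 2 `C=CCn1c(SCC(=O)Nc2ccc(/C(C)=N/O)cc2)nnc1-c1ccccc1` gives 63% in this assay.
Compound 3 `C=CCn1c(SCC(=O)Nc2ccc(/C(C)=N/O)cc2)nnc1-c1ccc(OC)cc1` gives 59% in this assay.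

Compound 2 is separated from compound 1 by a number 11 percentage points higher from compound 1 to compound 2 (beyond the scatter), a modest step beyond the scatter, whereas compound 3 sits within the scatter of it, a number 4 percentage points lower from compound 2 to compound 3 (within the scatter). Compound 4 `CCn1c(SCC(=O)Nc2ccc(/C(C)=N/O)cc2)nnc1-c1ccccc1` differs from compound 2 by methyl in place of vinyl on a saturated chain carbon bound to an aromatic nitrogen. Neither measured step touches this place: one changes a group on an aromatic carbon, the other adds methoxy on an aromatic carbon. Among the measured compounds shown here, no measured step therefore bears on the change, and only a step within the scatter is expected, a number 3 percentage points lower from compound 2 to compound 4 (within the scatter). Compound 4 is estimated at 60%, within 48% to 72%.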

Compound 4, a percentage reported as inhibition, in the whole organism at one dose (the size of the read-out at that dose, not a potency): 57%
For compound 4 the middle estimate is 3 percentage points above the measured one; the range from low to high includes it.
By their numbers in this assay, from the lowest: compounds 1, 4, 3 and 2 (each within the scatter of the next, the first and the last beyond it).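

Allyl to ethyl is the first change read at this place, on a saturated chain carbon bound to an aromatic nitrogen: in this assay it gives a number 6 percentage points lower from compound 2 to compound 4 (within the scatter). In this one pair, the vinyl end of the allyl group is therefore not required to keep inhibition within the scatter at the dose given. Nothing measured here accounts for the result.

On these data alone, a longer chain, such as butyl, or a chain ending in an amine or a carboxylic acid, remains open at this place. Also open, as far as these compounds go, is whether the same change reads alike with the methoxy group of compound 3 present.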